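Adding a methyl to compound 3: from isopropyl to sec-butyl

The compounds below may be only part of what the source reports. "The series", "measured", "known", "first", "only" and "open" are said of these compounds alone.

Three compounds share a core and differ at the side group on the chain carbon next to the ester. Compound 1 `N=C(N)NCCC[C@H](NC(=O)CN(c1ncnc2c1ncn2C1CCCCO1)C1CC1)C(=O)OCc1ccccc1` gives 61.6% in a functional assay on the whole organism (Tail, strain ICR) with Mus musculus as the target, in the tail flick test, with a stated time of 90 min, at a dose of 25 umol/kg by the oral route; on this read-out higher numbers stand for a stronger effect at the one dose given and lower numbers for a weaker effect. Compound 2 `O=C(OCc1ccccc1)[C@@H]1CCCN1C(=O)CN(c1nc(Cl)nc2[nH]cnc12)C1CC1` gives 43.3% in this assay. Compound 3 `CC(C)[C@H](NC(=O)CN(c1ncnc2c1ncn2C1CCCCO1)C1CC1)C(=O)OCc1ccccc1` gives 30.1% in this assay and so stands lowest of the three, with compound 2 the nearest neighbour and compound 1 the furthest.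

For the measured compounds named here, the one measured step that touches this position is a number 31.5 percentage points lower from compound 1 to compound 3 (beyond the scatter), a large fall that follows the swap of a group of seven heavy atoms with three nitrogens for a group of three carbons. Compound 4 `CC[C@H](C)[C@H](NC(=O)CN(c1ncnc2c1ncn2C1CCCCO1)C1CC1)C(=O)OCc1ccccc1` differs from compound 3 by methyl in place of hydrogen on a saturated chain carbon, three bonds along the chain from an amide-type nitrogen and a carbonyl carbon, which, cut one bond further out, reads isopropyl to sec-butyl. Going by the values given here, this is a much smaller change than the one from compound 1 to compound 3, and no measured pair mirrors it. With no closer guide, the change is expected to leave the read-out in this assay about where compound 3 lies, an estimated step of a number 1.9 percentage points higher from compound 3 to compound 4 (within the scatter) that stays within the usual scatter. Compound 4 is therefore estimated at 32%, with a range from 15% to 50%.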

Compound 4, a percentage reported as activity, at one dose (the size of the read-out at that dose, not a potency): 22.6%
The estimate for compound 4 lay 9.4 percentage points above the measured number, within the range that was stated.
By their numbers in this assay, from the lowest: compounds 4 and 3 (each within the scatter of the next); then compound 2; then compound 1.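

In this assay, methyl in place of hydrogen gives a number 7.5 percentage points lower from compound 3 to compound 4 (within the scatter) and so does not separate isopropyl from sec-butyl at this position on this read-out. The large gap to compound 1 also returns with the second side group made only of carbon, as a number 39 percentage points lower from compound 1 to compound 4 (beyond the scatter) shows, so the earlier fall is not confined to isopropyl and holds for both of these groups. No measurement on hand bears on what lies behind either step.

The compounds leave open whether a side group ending in a simple amine, a carboxylic acid or a longer unbranched chain would stand close to compound 1 or with compound 3 and compound 4 on this read-out. They also leave open whether the nitrogens or the length of the group in compound 1 account for the gap, and whether the picture seen at this one dose and time would hold at other doses.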